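Methyl in place of trifluoromethyl at two positions of the series

The source may report more compounds than this note shows. Statements on the series, on what has been measured and on what is new or still open speak of the compounds shown alone.

Measured so far, in a functional assay on HeLa cells (Homo sapiens) for antiproliferative activity, with a stated time of 24 h; a lower number here means a stronger inhibitor, a higher number a weaker inhibitor:
- Compound 1 `NC(=O)c1c(NC(=O)c2ccc(C(F)(F)F)cc2)sc2c1CCN(Cc1c(Cl)cccc1Cl)C2`: compound 1 gives > 50000 nM, which is a limit of the assay and not a number.
- Compound 2 `Cc1ccc(C(=O)Nc2sc3c(c2C(N)=O)CCN(Cc2c(Cl)cccc2Cl)C3)cc1`: compound 2 gives 47400 nM.
- Compound 3 `NC(=O)c1c(NC(=O)c2ccccc2Cl)sc2c1CCN(C(=S)Nc1ccccc1C(F)(F)F)C2`: compound 3 gives 26700 nM.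

Compound 1 and compound 2 share one core; the change between them is methyl in place of trifluoromethyl on an aromatic carbon. It gave an at least 1.0-fold lower number from compound 1 to compound 2 (0.02 log units; that floor lies within the scatter); since compound 1 sits at the limit of > 50000 nM in this assay, at which 1 of the 3 values shown sits, the size of that step is only a floor. Compound 3 carries a different core, and the difference between the two cores is not broken down here. Among the two numbers, compound 3 lies nearest compound 2, within the scatter.

Compound 4 `Cc1ccccc1NC(=S)N1CCc2c(sc(NC(=O)c3ccccc3Cl)c2C(N)=O)C1` is not yet measured. It differs from compound 3 by methyl in place of trifluoromethyl on an aromatic carbon. This is the same kind of change as that from compound 1 to compound 2, but the place differs: in compound 2 the methyl stands para to a large group, in compound 4 ortho to a large group. Resting on the earlier step, which was at most a small one, compound 4 is expected to show a 1.1-fold higher number from compound 3 to compound 4 (0.05 log units; within the scatter) in this assay. The estimate for compound 4 is 30000 nM, between 12000 nM and 50000 nM.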

Compound 4, half-maximal inhibitory concentration: > 50000 nM
Compound 4 ended at the assay's limit (the forecaster's own chance of this, stated with the estimate: 25%); at least 1.6-fold (0.22 log units) between middle value and limit.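

In this assay compound 4 gives > 50000 nM, which is a limit of the assay and not a number. Methyl in place of trifluoromethyl on this core gave an at least 1.8-fold higher number from compound 3 to compound 4 (0.27 log units; that floor lies within the scatter), so only a floor is known here, and it does not establish a real loss of antiproliferative activity. Whether the change acts alike on the two cores cannot be read, so the data neither show that it carries over nor show that it does not: the same change on two cores in this assay, an at least 1.0-fold lower number (0.02 log units; that floor lies within the scatter) from compound 1 to compound 2 and an at least 1.8-fold higher number (0.27 log units; that floor lies within the scatter) from compound 3 to compound 4; the limit leaves it open whether they differ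

Within the data shown here, how far the weak end of this series extends stays open, and no step that ends at the limit gives a full size: the limit of > 50000 nM in this assay, at which 2 of the 4 values shown sit. Also open is whether an amine, a carboxylic acid or a methoxy group in place of the trifluoromethyl of compound 3 would give a value inside the range of this assay.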